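Replacing the nitrile with methyl in the amide series

The source may hold more compounds than are shown below. What is called first, only, known or untested is meant among the compounds shown, and "the series" means these compounds.

Values so far in a physicochemical assay for solubility, read by nephelometry, measured as kinetic solubility, at pH 2, tested at 10 mg/mL (on this read-out lower numbers stand for lower solubility and higher numbers for higher solubility), for three compounds
- compound 1 `Cc1ccccc1C(=O)Nc1cc(Cl)ccn1` gives 25 ug/mL
- compound 2 `Cc1ccccc1C(=O)Nc1ccc(C#N)cn1` gives 6.3 ug/mL
- compound 3 `Cc1ccccc1C(=O)Nc1cc(C#N)ccn1` gives 50 ug/mL

In this assay compound 3 stands clearly above compound 2 and is not separated from compound 1 beyond the scatter. The next structure is compound 4 `Cc1ccnc(NC(=O)c2ccccc2C)c1` with methyl in place of cyano on an aromatic carbon, opposite the ring nitrogen (methyl in place of cyano on an aromatic carbon). Among the compounds with values here, one measured step bears on it, the change a 2.0-fold higher number from compound 1 to compound 3 (0.30 log units; within the scatter) at that same carbon, which stays within the scatter and involves no methyl. Within the data shown here, no measured step covers methyl, so a small upward step that does not clearly leave the scatter is expected, with its direction uncertain. The estimated change is a 1.6-fold higher number from compound 3 to compound 4 (0.20 log units; within the scatter) in this assay and remains an expectation. For compound 4 the expected value is 80 ug/mL and the expected range runs from 20 ug/mL to 320 ug/mL in this estimate.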

Compound 4, solubility: > 100 ug/mL
Compound 4: only a limit was reported; the forecaster's own chance of this, stated with the estimate: 10%; at least 1.2-fold (0.09 log units) between middle value and limit.
By their numbers in this assay, from the lowest: compound 2; then compounds 1 and 3 (each within the scatter of the next). At a limit, above all of these: compound 4.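

In this assay compound 4, with methyl opposite the ring nitrogen, gives > 100 ug/mL, which is a limit and not a number. Methyl in place of cyano at this carbon gives an at least 2.0-fold higher number from compound 3 to compound 4 (0.30 log units; that floor lies within the scatter), which leaves that separation unsettled. Methyl in place of chloro gives an at least 4.0-fold higher number from compound 1 to compound 4 (0.60 log units; beyond the scatter), the first change at this carbon to clear the scatter, and one value now stands at a limit: the limit of > 100 ug/mL in this assay, at which 1 of the 4 values shown sits.

Open, on these data alone, is how far either step runs past its floor. Also open, as far as these compounds go, is how a methoxy group or an amine at this carbon would read in this assay.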